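Para-halogen variation on the chalcone ring of a benzoxaborole series

The source may report more compounds than this note shows. Statements on the series, on what has been measured and on what is new or still open speak of the compounds shown alone.

Compound 1 `O=C(/C=C/c1ccc2c(c1)B(O)OC2)c1ccccc1` serves as the reference point of the pair measured so far. In a functional assay on MDA-MB-231 cells (Homo sapiens) for cytotoxicity, read by MTT assay, with a stated time of 48 h (a lower number here means a stronger inhibitor, a higher number a weaker inhibitor), compound 1 gives 2300 nM, the highest of the two numbers in hand. Compound 2 `O=C(/C=C/c1ccc2c(c1)B(O)OC2)c1ccc(F)cc1` carries fluoro in place of hydrogen on the same aromatic carbon; in this assay compound 2 gives 1600 nM, and the step of a 1.4-fold lower number from compound 1 to compound 2 (0.16 log units; within the scatter) is too small to be read as a real change.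

Compound 3 `O=C(/C=C/c1ccc2c(c1)B(O)OC2)c1ccc(Cl)cc1` is the next member, not yet measured. Relative to compound 1 the difference is chloro in place of hydrogen on an aromatic carbon, the change reading phenyl to 4-chlorophenyl when cut one bond further out. Among the measured compounds shown here, the only step that bears on it is the fluoro step, a 1.4-fold lower number from compound 1 to compound 2 (0.16 log units; within the scatter), which stayed inside the scatter. For the measured compounds named here, no chloro-for-hydrogen step exists in this set, so the expectation rests on that single halogen step alone.

On that basis compound 3 is expected to land near the two measured values, with a step of a 1.5-fold lower number from compound 1 to compound 3 (0.19 log units; within the scatter) and an estimated 1500 nM in this assay, ranging from 600 nM to 4000 nM.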

Compound 3, half-maximal inhibitory concentration: 7900 nM
Compound 3: the middle estimate sits 5.3-fold (0.72 log units) below what was measured; measured number above the stated range.
By their numbers in this assay, from the lowest: compounds 2 and 1 (each within the scatter of the next); then compound 3.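

At this carbon, para to a large group, the halogens do not behave alike in this assay: chloro in place of hydrogen gives a 3.4-fold higher number from compound 1 to compound 3 (0.54 log units; beyond the scatter) and so moves the number beyond the scatter, which the fluoro step did not do. Direct exchange of the two halogens gives a 4.9-fold higher number from compound 2 to compound 3 (0.69 log units; beyond the scatter) and makes compound 3 the weakest of the three, with both of its steps beyond the scatter, so the position distinguishes chloro from fluoro and the single fluoro step was a poor guide to halogens in general. Nothing available here accounts for the difference between the two halogens.

From the compounds shown here alone, the three compounds cover only hydrogen, fluoro and chloro at this one carbon of the shared core, so it remains open whether the weaker result is peculiar to chloro or would extend to bromo, and how a non-halogen group such as methoxy, an amine or a carboxylic acid would read here. Going by these compounds, whether chloro has the same effect at other carbons of this ring, or in other cell lines, also remains open.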